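A few compounds are considered here, and "the series" means these few. Any claim that something is new, unique, unknown or untested is made for them only; others in the source may bear on it.

Compound 1, `N=C(N)NCCC[C@H](NC(=O)CN(c1nc(Cl)nc2[nH]cnc12)C1CC1)C(=O)O`, gives 27.6% in a functional assay on the whole organism (Tail, strain ICR) with Mus musculus as the target, in the tail flick test, with a stated time of 90 min, at a dose of 25 umol/kg by the oral route; on this read-out lower numbers stand for a weaker effect and higher numbers for a stronger effect at the one dose given.
Compound 2, `C[C@@H](O)[C@H](NC(=O)CN(c1nc(Cl)nc2[nH]cnc12)C1CC1)C(=O)OCc1ccccc1`, gives 29.9%.
Compound 3, `N=C(N)NCCC[C@H](NC(=O)CN(c1nc(Cl)nc2[nH]cnc12)C1CC1)C(=O)OCc1ccccc1`, gives 30.4%.

On these numbers compound 3 holds the highest value of the three, yet its nearest neighbour, compound 2, sits only a number 0.5 percentage points higher from compound 2 to compound 3 (within the scatter), and compound 1 only a number 2.8 percentage points higher from compound 1 to compound 3 (within the scatter), so all three lie within the scatter of one another and no order among them can be claimed.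

Compound 4, `CSCC[C@H](NC(=O)CN(c1nc(Cl)nc2[nH]cnc12)C1CC1)C(=O)OCc1ccccc1`, differs from compound 3 in one place: a group of 2 heavy atoms (1 carbon, 1 sulfur; no ring) in place of a group of 5 heavy atoms (2 carbon, 3 nitrogen; no ring), on a saturated chain carbon, three bonds along the chain from an amide-type nitrogen and a carbonyl carbon.

Among the measured compounds shown here, the step that bears on this change is the one from compound 2 to compound 3, where the side chain on the same carbon was exchanged and the read-out moved a number 0.5 percentage points higher from compound 2 to compound 3 (within the scatter). The ester-for-acid step from compound 1 to compound 3 was likewise small, a number 2.8 percentage points higher from compound 1 to compound 3 (within the scatter). A further change of the side chain is therefore expected to leave the read-out essentially unchanged, with no step beyond the scatter in either direction. For compound 4 the expected step is a number 0.4 percentage points lower from compound 3 to compound 4 (within the scatter). Compound 4 is thus estimated at 30%, within a range of 19% to 41%.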

Compound 4, a percentage reported as activity, at one dose (the size of the read-out at that dose, not a potency): 44.6%
The estimate for compound 4 lay 14.6 percentage points below the measured number; the whole stated range lies below it.
By their numbers in this assay, from the lowest: compounds 1, 2 and 3 (each within the scatter of the next); then compound 4.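

In this assay the side chain on this saturated chain carbon proves able to move the read-out, which the earlier exchange, a number 0.5 percentage points higher from compound 2 to compound 3 (within the scatter), did not show. Methylsulfanyl in place of the nitrogen-rich group of 5 heavy atoms gives a number 14.2 percentage points higher from compound 3 to compound 4 (beyond the scatter), and 2-(methylsulfanyl)ethyl in place of 1-hydroxyethyl gives a number 14.7 percentage points higher from compound 2 to compound 4 (beyond the scatter), so the two comparisons, both beyond the scatter, point the same way. Nothing available accounts for this rise.

The compounds shown leave open whether the sulfur itself matters, since methoxy in place of methylsulfanyl, or an amine at the same place, would be needed to separate the atom from the chain. They also leave open how the free carboxylic acid in place of the benzyl ester would read with the methylsulfanyl side chain.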